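The source may report more compounds than this note shows. Statements on the series, on what has been measured and on what is new or still open speak of the compounds shown alone.

Measured compounds in a functional assay on HepG2 cells (Homo sapiens) for antiproliferative activity, read by MTT assay; on this read-out lower numbers stand for stronger inhibition and higher numbers for weaker inhibition:

- compound 1 `O=C1N=C(N2CCC[C@H]2C(=O)Nc2ccc3ncnc(Nc4cccc(Cl)c4)c3c2)S/C1=C/c1ccc(Br)s1`: > 50000 nM, a limit of the assay the limit of > 50000 nM in this assay, at which 1 of the 3 values shown sits.
- compound 2 `O=C1N=C(N2CCC[C@H]2C(=O)Nc2ccc3ncnc(Nc4cccc(Cl)c4)c3c2)S/C1=C/c1ccccc1Cl`: 28100 nM
- compound 3 `O=C1N=C(N2CCC[C@H]2C(=O)Nc2ccc3ncnc(Nc4cccc(Cl)c4)c3c2)S/C1=C/c1cccc(Br)n1`: 2700 nM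

Compound 3 carries the lowest of the two numbers given. Its nearest neighbour is compound 2, with the step of a 10-fold lower number from compound 2 to compound 3 (1.02 log units; beyond the scatter). Compound 1 gives only a limit and no number.

Compound 4 `O=C1N=C(N2CCC[C@H]2C(=O)Nc2ccc3ncnc(Nc4cccc(Cl)c4)c3c2)S/C1=C/c1ccccc1F` is the next member of the series. It differs from compound 3 in one place: 2-fluorophenyl in place of 6-bromopyridin-2-yl on a double-bonded chain carbon bound to a double-bonded ring carbon. Both compound 4 and compound 2 therefore carry a six-membered ring of carbon only with a single halogen on the double-bonded chain carbon, and differ only in which halogen it is.

The measured step that bears most directly on this change is a 10-fold lower number from compound 2 to compound 3 (1.02 log units; beyond the scatter), a large one, which runs from the 2-chlorophenyl member to the 6-bromopyridin-2-yl member. Read in the opposite direction, returning to a halogenated phenyl ring from the bromopyridinyl ring is expected to raise the number by a comparable amount. The step of an at least 1.7-fold lower number from compound 1 to compound 2 (0.25 log units; that floor lies within the scatter) adds little, as it lies at the floor of the scatter and starts from a limit.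

Compound 4 is therefore expected to sit close to compound 2, which means an estimated step of a 9.3-fold higher number from compound 3 to compound 4 (0.97 log units; beyond the scatter). The estimate for compound 4 in this assay is 25000 nM, within 8000 nM to 60000 nM.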

Compound 4, half-maximal inhibitory concentration: 18200 nM
Estimate against measurement, compound 4: 1.4-fold (0.14 log units) above; the range from low to high includes it.
By their numbers in this assay, from the lowest: compound 3; then compounds 4 and 2 (each within the scatter of the next). At a limit, above all of these: compound 1.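

In this assay, the step of a 6.7-fold higher number from compound 3 to compound 4 (0.83 log units; beyond the scatter) gives the series a second halogenated phenyl member on the double-bonded chain carbon, so the lower number of compound 3 no longer rests on a comparison with the 2-chlorophenyl group alone. The step of a 1.5-fold lower number from compound 2 to compound 4 (0.19 log units; within the scatter) lies within the scatter, so fluoro in place of chloro on an aromatic carbon gives no readable difference here, and compounds 2 and 4 sit together as a pair, with the 6-bromopyridin-2-yl group of compound 3 apart from both. The step of an at least 2.7-fold lower number from compound 1 to compound 4 (0.43 log units; beyond the scatter) lies beyond the scatter, but it starts from a limit and gives only a floor for the change from the 5-bromothiophen-2-yl group: the limit of > 50000 nM in this assay, at which 1 of the 4 values shown sits.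

Going by these compounds, the change from compound 3 to compound 4 removes the ring nitrogen and the bromine together, so it remains open which of the two carries the step; a pyridin-2-yl ring without bromine and a bromophenyl ring are the comparisons that would separate them. Also open, on these data alone, is how a ring carrying a dimethylamino group or a carboxylic acid would read at this place.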